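The source may report more compounds than this note shows. Statements on the series, on what has been measured and on what is new or still open speak of the compounds shown alone.

Working notes on the series in a functional assay on LOX IMVI cells (Homo sapiens) for inhibition, read by sulforhodamine B assay, with a stated time of 48 h; on this read-out lower numbers stand for stronger inhibition of growth and higher numbers for weaker inhibition of growth.

Of the compounds shown here, two carry a number so far. Compound 1, `O=C(Nc1cccc(-n2cc(-c3ccncc3)c(-c3ccc(Cl)c(O)c3)n2)c1)Nc1cccc(C(F)(F)F)c1`, gives 9580 nM. Compound 2, `COc1cc(-c2nn(-c3cccc(NC(=O)Nc4ccc(Cl)c(C(F)(F)F)c4)c3)cc2-c2ccncc2)ccc1Cl`, gives 4610 nM, the lower of the two numbers; the gap to compound 1 lies beyond the usual scatter. Compound 1 and compound 2 differ in more than one place, so the two values stand side by side without a single step between them.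

Compound 3, `O=C(Nc1cccc(-n2cc(-c3ccncc3)c(-c3ccc(Cl)c(O)c3)n2)c1)Nc1ccc(Cl)c(C(F)(F)F)c1`, has not been measured yet. Against compound 2 the change is hydrogen in place of methyl on an oxygen on an aromatic ring; the rest of the structure is kept. No step between measured compounds shows this change alone, so the size of its effect is not known from the numbers shown. Among the measured compounds shown here, the only hydroxy compound measured, compound 1, sits at the higher number, but it also carries a different aryl on the urea, so that comparison does not separate the two changes.

The expectation for compound 3 is a number somewhat above compound 2, with the step from compound 2 to compound 3 estimated at a 1.5-fold higher number from compound 2 to compound 3 (0.18 log units; within the scatter). Compound 3 is therefore expected near 7000 nM, within a range from 3000 nM to 16000 nM.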

Compound 3, concentration for total growth inhibition: 1150 nM
Estimate against measurement, compound 3: 6.1-fold (0.78 log units) above; the whole stated range lies above it.
By their numbers in this assay, from the lowest: compound 3; then compound 2; then compound 1.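

In this assay, replacing methoxy with hydroxy alone, 4-chloro-3-methoxyphenyl to 4-chloro-3-hydroxyphenyl, gives a 4.0-fold lower number from compound 2 to compound 3 (0.60 log units; beyond the scatter), so this position responds to the change by an amount beyond the scatter, which the earlier pair of compounds could not separate from the difference on the urea aryl. With the hydroxy kept, chloro in place of hydrogen on an aromatic carbon of the urea aryl gives an 8.3-fold lower number from compound 1 to compound 3 (0.92 log units; beyond the scatter), so the two single changes point the same way and compound 3 holds the lowest number of the three, with both of its steps beyond the scatter. Nothing measured here speaks to the reason for either step.

From the compounds shown here alone, whether the hydroxy step keeps its size on the aryl without the chloro remains open, so the two changes cannot yet be called additive or dependent on each other. Also open, going by these compounds, is how this position responds to other groups in place of the hydroxy, such as an amine, an ethoxy or a carboxylic acid.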